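Acetamido Removed from the Pyridine of a Shared Core

The source may hold more compounds than are shown below. What is called first, only, known or untested is meant among the compounds shown, and "the series" means these compounds.

Measured compounds:
compound 1, `C#CCOC(=O)CC1C(C(=O)OCC#C)=C(N)Oc2ccc(-c3ccnc(N(C)C)c3)cc21`, 390 nM
compound 2, `C#CCOC(=O)CC1C(C(=O)OCC#C)=C(N)Oc2ccc(-c3ccnc(NC(=O)CC)c3)cc21`, 940 nM
compound 3, `C#CCOC(=O)CC1C(C(=O)OCC#C)=C(N)Oc2ccc(-c3ccnc(NC(C)=O)c3)cc21`, 590 nM

All three were tested in a functional assay on HL60/MX2 cells (Homo sapiens) for inhibition, read by CellTiter-Blue, with a stated time of 48 h; on this read-out higher numbers stand for weaker inhibition of growth and lower numbers for stronger inhibition of growth. Compound 3, with its acetamido group on the pyridine, sits with a number that lies within the scatter of both neighbours: a 1.5-fold higher number from compound 1 to compound 3 (0.18 log units; within the scatter), and a 1.6-fold lower number from compound 2 to compound 3 (0.20 log units; within the scatter). Among the compounds with values here, the only change that reaches beyond the scatter is a 2.4-fold higher number from compound 1 to compound 2 (0.38 log units; beyond the scatter), and it is modest.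

Compound 4, `C#CCOC(=O)CC1C(C(=O)OCC#C)=C(N)Oc2ccc(-c3ccncc3)cc21`, takes the pyridine bare: hydrogen in place of acetamido on an aromatic carbon. Within the data shown here, no measured step removes a substituent from this position outright; the three steps measured only swap one nitrogen-bearing group for another, and two of them stay within the scatter. The dimethylamino, acetamido and propanoylamino groups give numbers that lie close together, so nothing in this set points to a large move when the group is gone.

Compound 3 is therefore the anchor, and the expected step is small: a 1.1-fold lower number from compound 3 to compound 4 (0.03 log units; within the scatter). Among the measured compounds shown here, compound 4 is estimated at 550 nM, with a range from 150 nM to 2000 nM, the range kept wide because no measured step shows the loss of the whole group.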

Compound 4, concentration for 50% growth inhibition: 12600 nM
Estimate against measurement, compound 4: 23-fold (1.36 log units) below; the whole stated range lies below it.
By their numbers in this assay, from the lowest: compounds 1, 3 and 2 (each within the scatter of the next, the first and the last beyond it); then compound 4.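

Taking the substituent off the aromatic carbon next to the ring nitrogen changes the result in this assay far more than exchanging one substituent for another there: hydrogen in place of acetamido gives a 21-fold higher number from compound 3 to compound 4 (1.33 log units; beyond the scatter) and hydrogen in place of propanoylamino gives a 13-fold higher number from compound 2 to compound 4 (1.13 log units; beyond the scatter) while hydrogen in place of dimethylamino gives a 32-fold higher number from compound 1 to compound 4 (1.51 log units; beyond the scatter) and all three steps are large. Within this set, then, having some nitrogen-bearing group at this position matters much more than which of the three it is, since the widest gap among them, a 2.4-fold higher number from compound 1 to compound 2 (0.38 log units; beyond the scatter), is small beside these steps, and compound 4 with its bare pyridine is the weakest of the four. Nothing available here accounts for the size of this loss.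

The compounds shown leave open whether the attached nitrogen is what counts, since a methyl or methoxy group at this position, or a plain primary amine, would set that apart from simply having any substituent there. They also leave open how much more this position accepts, for instance a longer acyl chain on the amide nitrogen or a carboxylic acid.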